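Carrying the Tert-Butyl-for-Phenoxy Step to Compound 4

The source may hold more compounds than are shown below. What is called first, only, known or untested is meant among the compounds shown, and "the series" means these compounds.

Compound 1 `CN(C)CCC(OC(=O)Nc1ccc(Oc2ccccc2)cc1)c1ccc(Cl)cc1`: 191 nM
Compound 2 `CN(C)CCC(OC(=O)Nc1ccc(C(C)(C)C)cc1)c1ccc(Cl)cc1`: 1820 nM
Compound 3 `CN(C)CCC(NC(=O)Nc1ccc(Oc2ccccc2)cc1)c1ccc(Cl)cc1`: 110 nM

Of the compounds shown here, three have been measured in an assay on NIH3T3 cells with Urotensin-2 receptor (Homo sapiens) as the target; on this read-out lower numbers stand for an effect already at smaller amounts and higher numbers for an effect only at larger amounts of compound. Compound 1 and compound 2 share one core, while compound 3 rests on another; the difference between the two cores is not broken down here. Compound 3 and compound 1 lie within the scatter of each other, whereas compound 2 sits apart from both. For the measured compounds named here, the one single-point change measured so far is tert-butyl in place of phenoxy on an aromatic carbon, and it gave a 9.5-fold higher number from compound 1 to compound 2 (0.98 log units; beyond the scatter).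

Compound 4 `CN(C)CCC(NC(=O)Nc1ccc(C(C)(C)C)cc1)c1ccc(Cl)cc1` is not yet measured. It relates to compound 3 exactly as compound 2 relates to compound 1: tert-butyl in place of phenoxy on an aromatic carbon. The two place descriptions read the same word for word, so this is the same change carried onto the other core. With a single example of the step to draw on, the expectation rests on compound 1 and compound 2 alone. The step is expected to be about a 9.1-fold higher number from compound 3 to compound 4 (0.96 log units; beyond the scatter), close to the earlier one, because it starts from compound 3 at 110 nM. Compound 4 is therefore estimated at 1000 nM, most likely between 400 nM and 2600 nM.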

Compound 4, half-maximal effective concentration: 275 nM
Estimate against measurement, compound 4: 3.6-fold (0.56 log units) above; the whole stated range lies above it.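

In this assay, tert-butyl in place of phenoxy gave a higher number on both cores, but the size of the step did not carry over, with a 2.5-fold higher number from compound 3 to compound 4 (0.40 log units; beyond the scatter) and the two steps differing clearly: the same change on two cores in this assay, a 9.5-fold higher number (0.98 log units; beyond the scatter) from compound 1 to compound 2 and a 2.5-fold higher number (0.40 log units; beyond the scatter) from compound 3 to compound 4, 3.8-fold (0.58 log units) apart, beyond the scatter of two such steps The direction of the change therefore held across this one pair of cores, while its size could not simply be transferred from one core to the other. These two steps alone do not show why they differ, nor whether the same gap would appear with any other exchanged group or on any further core.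

The compounds shown leave open how other groups at this place, such as methoxy or trifluoromethyl, would behave on the two cores, and whether their steps would also differ in size. They also leave open whether the gap between the steps would persist with a different amine in place of the dimethylamino group or with fluorine in place of the chlorine.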